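Swapping cyclopentyl for methyl on a nontoxic series

The source may report more compounds than this note shows. Statements on the series, on what has been measured and on what is new or still open speak of the compounds shown alone.

Compound 1 `COc1ccc(-c2cnc(NC(=O)c3cnc[nH]3)n2C)cc1`: > 100000 nM
Compound 2 `CCCn1c(-c2ccc(OC)cc2)cnc1NC(=O)c1ccc(F)cc1`: > 100000 nM
Compound 3 `COc1ccc(-c2cnc(NC(=O)c3ccc(F)cc3)n2C2CCCC2)cc1`: > 100000 nM

All three entries come from a toxicity assay on THP-1 cells (Homo sapiens) for inhibition (on this read-out lower numbers stand for higher toxicity in this test and higher numbers for lower toxicity in this test), and each is a limit of the test rather than a true number. The overall picture is simple: the limit of > 100000 nM in this assay, at which 3 of the 3 values shown sit. Compound 3 therefore has no exact position on the scale, and its > 100000 nM is only a limit.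

Compound 4 `COc1ccc(-c2cnc(NC(=O)c3ccc(F)cc3)n2C)cc1` differs from compound 3 in one group: methyl in place of cyclopentyl on an aromatic nitrogen. The change sits on an aromatic nitrogen of a five-membered aromatic ring, next to the ring atom that bears a 4-methoxyphenyl group.

Going by the values given here, the only measured step at this nitrogen is a step that the two limits leave unreadable from compound 2 to compound 3. Its size cannot be read, so it offers no number to carry over. The expectation therefore rests on the limit shared by the measured compounds, (the limit of > 100000 nM in this assay, at which 3 of the 3 values shown sit), and no step beyond the usual scatter is expected in this assay. The expected change is a number no higher from compound 3 to compound 4 (the limit leaves the size open), and the test may well report only a limit again. For compound 4 the estimate is 100000 nM, with an expected range from 40000 nM to 200000 nM.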

Compound 4, half-maximal cytotoxic concentration: >= 50000 nM
Compound 4 ended at the assay's limit (the forecaster's own chance of this, stated with the estimate: 85%); the middle value does not contradict the limit.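

Compound 4 gives >= 50000 nM, which is a limit of the assay and not a true number. Compound 1, compound 2 and compound 3 also stand only at limits in this assay, and none of their steps to compound 4 can be read. The compounds shown leave open what true value any of them has on this read-out.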